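The source may report more compounds than this note shows. Statements on the series, on what has been measured and on what is new or still open speak of the compounds shown alone.

Measured so far:
- compound 1 `CCN(CC)c1ccc(/C=N/NC(N)=S)c(O)c1`: 900 nM
- compound 2 `Oc1ccccc1/C=N/NC(=S)Nc1ccccc1`: 2400 nM

In a functional assay on HEp-2 cells (Homo sapiens) for antiproliferative activity, read by MTT assay, with a stated time of 72 h (on this read-out higher numbers stand for weaker inhibition and lower numbers for stronger inhibition), compound 2 gives 2400 nM, the highest of the two numbers; compound 1 gives 900 nM, a lower number by a margin beyond the usual scatter. Within the data shown here, compound 2 and compound 1 differ in more than one place, so no single step between them is available.

Compound 3 `CCN(CC)c1ccc(/C=N/NC(=S)Nc2ccccc2)c(O)c1` is not yet measured. It carries the change (diethylamino in place of hydrogen on an aromatic carbon), diethylamino in place of hydrogen on an aromatic carbon, the same diethylamino that compound 1 bears, while keeping the phenyl-bearing end of compound 2. Compound 1 shows that the combination of diethylamino with the shared core gives a lower number than compound 2 in this assay; the bare thiosemicarbazone end is not held constant, so the step is expected toward lower numbers but only of moderate size. Compound 3 is estimated at 900 nM (300 nM to 3000 nM), which means an expected step of a 2.7-fold lower number from compound 2 to compound 3 (0.43 log units; beyond the scatter).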

Compound 3, half-maximal inhibitory concentration: 300 nM
The estimate for compound 3 lay 3.0-fold (0.48 log units) above the measured number, within the range that was stated.
By their numbers in this assay, from the lowest: compound 3; then compound 1; then compound 2.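

In this assay, diethylamino in place of hydrogen on an aromatic carbon, meta to a hydroxy group and para to a large group, can now be read as a single change with the phenyl-bearing end held constant (an 8.0-fold lower number from compound 2 to compound 3 (0.90 log units; beyond the scatter)). Phenyl in place of hydrogen on an amide-type nitrogen can also be read alone with diethylamino held constant (a 3.0-fold lower number from compound 1 to compound 3 (0.48 log units; beyond the scatter)), so each change on its own gives a lower number by a margin beyond the scatter. Nothing at hand accounts for either step.

The compounds shown leave open whether dimethylamino or methoxy on the same aromatic carbon would give a step of similar size. They also leave open whether methyl or benzyl on the amide-type nitrogen would match phenyl.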